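A few compounds are considered here, and "the series" means these few. Any claim that something is new, unique, unknown or untested is made for them only; others in the source may bear on it.

Measured so far:
- Compound 1, `COC(=O)/C=C/c1ccc2c(c1)C(=O)C(=O)N2Cc1ccc(C)cc1`: 40 nM
- Compound 2, `CC(C)(C)OC(=O)/C=C/c1ccc2c(c1)C(=O)C(=O)N2Cc1ccc(Br)cc1`: 2050 nM

These two compounds share a core and were tested in a functional assay on HepG2 cells (Homo sapiens) for cytotoxicity, read by MTT assay, with a stated time of 48 h; a lower number here means a stronger inhibitor, a higher number a weaker inhibitor. Compound 1 has the lowest number of the two, and compound 2 stands well apart from it, beyond the scatter of repeated measurements. Compound 2 differs from compound 1 in more than one place, so the two values alone cannot say which part of the structure carries the difference.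

Compound 3, `COC(=O)/C=C/c1ccc2c(c1)C(=O)C(=O)N2Cc1ccc(Cl)c(Cl)c1`, has not yet been measured. It differs from compound 1 in one place: 3,4-dichlorophenyl in place of 4-methylphenyl on a saturated chain carbon bound to an amide-type nitrogen in a ring. Compound 2 also carries a halogen on the phenyl at this place, and its number is high, but its ester differs as well, so the evidence for what the halogens do on their own is thin. A step of moderate size toward a higher number is expected from compound 1 to compound 3, and it may well stay within the scatter. Compound 3 is therefore expected to give about 120 nM, likely between 30 nM and 600 nM, which means an expected 3.0-fold higher number from compound 1 to compound 3 (0.48 log units; beyond the scatter).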

Compound 3, half-maximal inhibitory concentration: 160 nM
Compound 3: middle estimate off by 1.3-fold (0.12 log units), on the low side; the measured number falls inside the stated range.
By their numbers in this assay, from the lowest: compound 1; then compound 3; then compound 2.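

Among the compounds shown here, compound 3 gives the first clean reading of this position: in this assay, putting 3,4-dichlorophenyl in place of 4-methylphenyl on the saturated chain carbon bound to an amide-type nitrogen in a ring, with the rest of the structure unchanged, gives a 4.0-fold higher number from compound 1 to compound 3 (0.60 log units; beyond the scatter) in a modest step. The number therefore responds to what the phenyl ring carries at this place, yet compound 3 at 160 nM shows that a phenyl with two chlorines on it still leaves clear activity in these cells. No measurement at hand explains why the number moves in this direction.

This single change removes the methyl and adds two chlorines at once, so the part played by each remains unresolved, and a phenyl carrying one chlorine or a methoxy group at this place would help to separate them. On these data alone, the ester also remains open, since compound 2 differs from compound 1 in more than one place, and a carboxylic acid in place of the ester would test that end of the molecule directly.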